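Benzylamino replaces cyanomethoxy on the shared core

A few compounds are considered here, and "the series" means these few. Any claim that something is new, unique, unknown or untested is made for them only; others in the source may bear on it.

Measured compounds:
Compound 1 `CCC1(Cc2ccccc2)OS(=O)(=O)C=C1OCc1ccc(OC)cc1` gives > 200000 nM in an ADME assay on HEL cells (Homo sapiens) for cytotoxicity, with a stated time of 3 days; a higher number here means that more compound is tolerated, a lower number that less compound is tolerated; this value is a limit of the assay.
Compound 2 `CCC1(Cc2ccccc2)OS(=O)(=O)C=C1OCC#N` gives > 200000 nM in this assay; this value is a limit.
Compound 3 `CCC1(Cc2ccccc2)OS(=O)(=O)C=C1OC(=O)c1ccccc1` gives > 200000 nM in this assay; this value is a limit.

Compound 2 stands at a limit in this assay, and the two further values shown are limits as well, so no number places it above or below the others. The step that the two limits leave unreadable from compound 1 to compound 2 and the step that the two limits leave unreadable from compound 2 to compound 3 are both unreadable, since the limit of > 200000 nM in this assay, at which 3 of the 3 values shown sit, describes where every measured value sits.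

The unmeasured compound 4 `CCC1(Cc2ccccc2)OS(=O)(=O)C=C1NCc1ccccc1` differs from compound 2 by benzylamino in place of cyanomethoxy on a double-bonded ring carbon. Going by the values given here, no measured step touches this position or this kind of group, so the only bearing the measured steps have is that the whole series remains at the limit regardless of the group on the oxygen of the core. The expected step is therefore none beyond the scatter: compound 4 is estimated to stay where the others stand, with an expected step of a number no higher from compound 2 to compound 4 (the limit leaves the size open).

Compound 4 is expected to give 200000 nM in this assay, within a range from 100000 nM to 400000 nM, most likely reported again as a limit.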

Compound 4, half-maximal cytotoxic concentration: 92000 nM
The estimate for compound 4 lay 2.2-fold (0.34 log units) above the measured number; measured number below the stated range.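

In this assay, going by these compounds alone, benzylamino in place of cyanomethoxy on a double-bonded ring carbon gives an at least 2.1-fold lower number from compound 2 to compound 4 (0.33 log units; beyond the scatter), so a change at this position can bring the series off its limit, something the earlier compounds, all joined to this carbon through an oxygen, did not show. The steps among compounds 1, 2 and 3 cannot be read, and compound 4 is the only compound shown that gives a number rather than a limit: the limit of > 200000 nM in this assay, at which 3 of the 4 values shown sit. The value of compound 2 is itself a limit, so the printed step fixes only the smallest size the change can have, and the real drop could be larger.

The change replaces the oxygen with a nitrogen and the cyanomethyl part with a benzyl part in a single move, so the compounds shown do not tell which of the two carries the step. They also leave open how a plain unsubstituted amine or a phenethylamino group on this carbon would stand in this assay, and thus whether the aromatic ring or the length of the chain on the nitrogen matters.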